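The source may report more compounds than this note shows. Statements on the series, on what has been measured and on what is new or still open speak of the compounds shown alone.

Series notes, phenylsulfonyl benzyl analogues of the shared core.

Compound 1 `Cc1c(Cc2ccc(C(F)(F)F)cc2S(=O)(=O)c2ccccc2)c2c(n1CC(=O)O)CCNC2=O` gives 13 nM in a functional assay on CHO.K1 cells for antagonist activity at prostaglandin D2 receptor 2 (Homo sapiens), read by GTPgammaS binding, with a stated time of 1 h; on this read-out higher numbers stand for weaker inhibition and lower numbers for stronger inhibition. Compound 2 `CNC(=O)c1ccc(Cc2c3c(n(CC(=O)O)c2C)CCNC3=O)c(S(=O)(=O)c2ccccc2)c1` gives 10 nM in this assay; the move a 1.3-fold lower number from compound 1 to compound 2 (0.11 log units; within the scatter) stays inside the scatter, so the two carry the same number for practical purposes. Compound 3 `Cc1c(Cc2ccccc2S(=O)(=O)c2cccc(Cl)c2)c2c(n1CC(=O)O)CCNC2=O` gives 4 nM in this assay, the lowest number of the three measured, standing beyond the scatter from both compound 2 and compound 1.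

Compound 4 `CNC(=O)c1cccc(S(=O)(=O)c2ccccc2Cc2c3c(n(CC(=O)O)c2C)CCNC3=O)c1` is not yet measured. The change from compound 3 is methylcarbamoyl in place of chloro on an aromatic carbon. Among the measured compounds shown here, the only measured step that bears on it is the entry of the same methylcarbamoyl group, though on the other ring and in place of trifluoromethyl rather than chloro: a 1.3-fold lower number from compound 1 to compound 2 (0.11 log units; within the scatter), a step within the scatter. For the measured compounds named here, no pair among the measured compounds exchanges chloro for methylcarbamoyl on the sulfonyl-bearing ring, so the transfer is indirect. On that evidence no step beyond the scatter is expected in this assay, with the uncertainty widened for the different ring. Compound 4 is therefore estimated at 5 nM, range 2 nM to 14 nM, which corresponds to an expected step of a 1.3-fold higher number from compound 3 to compound 4 (0.10 log units; within the scatter).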

Compound 4, half-maximal inhibitory concentration: 240 nM
Estimate against measurement, compound 4: 48-fold (1.68 log units) below; measured number outside the range, above it.
By their numbers in this assay, from the lowest: compound 3; then compounds 2 and 1 (each within the scatter of the next); then compound 4.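

In this assay, among the compounds shown here, this aromatic carbon proves far less tolerant of the methylcarbamoyl group than the earlier compounds indicated, with the change from 3-chlorophenyl to 3-(methylcarbamoyl)phenyl giving a 60-fold higher number from compound 3 to compound 4 (1.78 log units; beyond the scatter). The same group therefore does not behave alike on the two rings: on the other ring, where it replaces trifluoromethyl, the result is a 1.3-fold lower number from compound 1 to compound 2 (0.11 log units; within the scatter), whereas here the step is large. Nothing available accounts for the size of this step.

Going by these compounds, it remains open whether the step belongs to the entry of methylcarbamoyl or to the departure of chloro, and a fluoro or methyl group on this carbon would help to separate the two. A dimethylcarbamoyl group or a primary carboxamide here would further show whether the amide hydrogen or the methyl group of the amide matters.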